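Pyridine amidrazone thiosemicarbazides: a methyl-to-hydrogen step on A-431

This account rests on a few compounds, and the source may have more. Where it says the series, first, only, none or still open, it means among the compounds named here.

Measured compounds:
compound 1 `N/C(=N\NC(=S)N1CCCCCC1)c1ccccn1`: 77.5%
compound 2 `Cc1ccnc(/C(N)=N/NC(=S)N2CCN(c3ccccn3)CC2)c1`: 75.5%
compound 3 `Cc1ccnc(/C(N)=N/NC(=S)N2CCCCCC2)c1`: 71%

Of the compounds shown here, three have been tested in a functional assay on A-431 cells (Homo sapiens) for cytotoxicity, read by MTT assay, with a stated time of 72 h, tested at 100 uM; on this read-out higher numbers stand for more inhibition of growth at the one concentration tested and lower numbers for less inhibition of growth. Compound 1 `N/C(=N\NC(=S)N1CCCCCC1)c1ccccn1` gives 77.5%, compound 2 `Cc1ccnc(/C(N)=N/NC(=S)N2CCN(c3ccccn3)CC2)c1` gives 75.5%, and compound 3 `Cc1ccnc(/C(N)=N/NC(=S)N2CCCCCC2)c1` gives 71%; all three values lie within the scatter of one another. Compound 1 differs from compound 3 in one place, (hydrogen in place of methyl on an aromatic carbon), and that step reads a number 6.5 percentage points higher from compound 3 to compound 1 (within the scatter). Compound 2 and compound 3 share the same change of ring substituent but differ in their cores, and the difference between the two cores is not broken down here.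

Compound 4 `N/C(=N\NC(=S)N1CCN(c2ccccn2)CC1)c1ccccn1` has not yet been measured. It differs from compound 2 by hydrogen in place of methyl on an aromatic carbon, the same change as from compound 3 to compound 1, at the same place. Because the earlier step was a number 6.5 percentage points higher from compound 3 to compound 1 (within the scatter), the step from compound 2 to compound 4 in this assay is expected to be about a number 2.5 percentage points higher from compound 2 to compound 4 (within the scatter), small and within the scatter. On that basis compound 4 is estimated to give 78% in this assay, most likely between 66% and 89%.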

Compound 4, percent growth inhibition at one concentration: 91.9%
The estimate for compound 4 lay 13.9 percentage points below the measured number, outside the stated range (above it).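

In this assay, the change from 4-methylpyridin-2-yl to pyridin-2-yl reads a number 16.4 percentage points higher from compound 2 to compound 4 (beyond the scatter). Set beside the earlier step on the other core, its size cannot be told apart from that step: the same change on two cores in this assay, a number 6.5 percentage points higher (within the scatter) from compound 3 to compound 1 and a number 16.4 percentage points higher (beyond the scatter) from compound 2 to compound 4, 9.9 percentage points apart, within the scatter of two such steps. Among these compounds, the change can thus be carried between these two cores with no difference between the steps beyond the scatter, although only the step ending at compound 4 itself stands beyond the scatter, and two pairs show neither that the core leaves the size of the step untouched nor that the step would hold on a further core.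

The compounds shown leave open how a chlorine atom, a methoxy group or an amine on this same aromatic carbon would compare with methyl and hydrogen. Also open, going by these compounds, is whether the step would keep its size at concentrations other than the single one used here, as one concentration gives no full measure of potency.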